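This account rests on a few compounds, and the source may have more. Where it says the series, first, only, none or still open, it means among the compounds named here.

Measured compounds:
Compound 1, `CC(C)[C@H](NCCC1OCC(C)(C)CO1)C(=O)N[C@H]1[C@@H](OCc2ccccc2)O[C@H](COCc2ccccc2)[C@@H](OCc2ccccc2)[C@@H]1OCc1ccccc1`: in a functional assay on the whole organism (Ear, strain ICR) for inhibition, with Mus musculus as the target, with stated times of 30 min and 2 h, at a dose of 10 umol/kg by the oral route (on this read-out higher numbers stand for more inhibition at the one dose given (going by the name of the read-out) and lower numbers for less inhibition), compound 1 gives 86.2%.
Compound 2, `C[C@H](NCCC1OCC(C)(C)CO1)C(=O)N[C@H]1[C@@H](OCc2ccccc2)O[C@H](COCc2ccccc2)[C@@H](OCc2ccccc2)[C@@H]1OCc1ccccc1`: compound 2 gives 90.3%.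
Compound 3, `CC(=O)OC[C@H]1O[C@H](OC(C)=O)[C@H](NC(=O)[C@@H](NCCC2OCC(C)(C)CO2)C(C)C)[C@@H](OC(C)=O)[C@@H]1OC(C)=O`: compound 3 gives 70.6%.

Compound 1 and compound 2 share one core and differ in a single place: methyl in place of isopropyl on a saturated chain carbon bound to an amine nitrogen and a carbonyl carbon. Across this change the read-out moved by a number 4.1 percentage points higher from compound 1 to compound 2 (within the scatter), a difference that falls within the scatter, so the two compounds cannot be ordered against each other on this read-out. Compound 3 carries a different core; how the two cores differ is not broken down here. What is clear is that compound 3 stands lower than both compound 1 and compound 2, and both of those gaps lie beyond the scatter.

Compound 4, `CC(=O)OC[C@H]1O[C@H](OC(C)=O)[C@H](NC(=O)[C@H](C)NCCC2OCC(C)(C)CO2)[C@@H](OC(C)=O)[C@@H]1OC(C)=O`, has not yet been measured. It differs from compound 3 by methyl in place of isopropyl on a saturated chain carbon bound to an amine nitrogen and a carbonyl carbon, and since the place of the change is described in the same words as for the pair of compound 1 and compound 2, this is the same change made on the second core. Because the same change gave a number 4.1 percentage points higher from compound 1 to compound 2 (within the scatter), the expected step here is a number 3.4 percentage points higher from compound 3 to compound 4 (within the scatter), that is, a move small enough to sit inside the usual scatter. Going by the values given here, there is no second example of this change on the core of compound 3, so the range is kept wide. Compound 4 is therefore expected to give 74%, with a likely span from 58% to 88%.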

Compound 4, a percentage reported as inhibition, in the whole organism at one dose (the size of the read-out at that dose, not a potency): 84.2%
Compound 4: middle estimate off by 10.2 percentage points, on the low side; measured number inside the range.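

In this assay, methyl in place of isopropyl on a saturated chain carbon bound to an amine nitrogen and a carbonyl carbon gave a number 13.6 percentage points higher from compound 3 to compound 4 (beyond the scatter), while the same change on the other core gave a number 4.1 percentage points higher from compound 1 to compound 2 (within the scatter). Set side by side, the two steps point the same way and cannot be told apart in size: the same change on two cores in this assay, a number 4.1 percentage points higher (within the scatter) from compound 1 to compound 2 and a number 13.6 percentage points higher (beyond the scatter) from compound 3 to compound 4, 9.5 percentage points apart, within the scatter of two such steps. Going by these compounds alone, this shows that, on these two cores, the change carried over in direction with no measurable dependence on the core, although only on the core of compound 3 does the step itself lie beyond the scatter; it does not show that the step has one fixed size, or that the same would hold on any further core, since each core supplies only a single pair.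

The compounds shown leave open what a hydrogen, a longer chain or a phenyl ring would give at that same carbon, since isopropyl and methyl are the only two groups seen there. They also leave open how free hydroxyl groups would compare on the core of compound 3, and whether the steps would look the same at any other dose, as the read-out comes from one dose and is not a potency.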